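The source may hold more compounds than are shown below. What is called first, only, known or untested is meant among the compounds shown, and "the series" means these compounds.

Compounds measured in an assay on CHO cells for displacement of a labelled ligand from transient receptor potential cation channel subfamily V member 1 (Homo sapiens), read by scintillation counting, with a stated time of 60 min; a lower number here means a stronger inhibitor, a higher number a weaker inhibitor:
compound 1, `CC(C(=O)NCc1ccc(C(F)(F)F)nc1N(Cc1ccccc1)S(=O)(=O)c1ccc(F)cc1)c1ccc(NS(C)(=O)=O)c(F)c1`: 1.56 nM
compound 2, `CC(C(=O)NCc1ccc(C(F)(F)F)nc1N(Cc1ccc(F)cc1)S(=O)(=O)c1ccc(F)cc1)c1ccc(NS(C)(=O)=O)c(F)c1`: 0.71 nM
compound 3, `CC(C(=O)NCc1ccc(C(F)(F)F)nc1N(Cc1ccc(Cl)cc1)S(=O)(=O)c1ccc(F)cc1)c1ccc(NS(C)(=O)=O)c(F)c1`: 0.9 nM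

Compound 3 holds the second highest of the three numbers. Its nearest neighbour is compound 2, see a 1.3-fold higher number from compound 2 to compound 3 (0.10 log units; within the scatter); its furthest is compound 1, see a 1.7-fold lower number from compound 1 to compound 3 (0.24 log units; within the scatter). Both gaps sit within the scatter, so compound 3 cannot be set apart from either on these numbers.

Compound 4, `COc1ccc(CN(c2nc(C(F)(F)F)ccc2CNC(=O)C(C)c2ccc(NS(C)(=O)=O)c(F)c2)S(=O)(=O)c2ccc(F)cc2)cc1`, is not yet measured. Relative to compound 3 the change is methoxy in place of chloro on an aromatic carbon.

Bearing on this step: all three measured steps vary the same aromatic carbon. a 2.2-fold lower number from compound 1 to compound 2 (0.34 log units; beyond the scatter) is the only one beyond the scatter; a 1.7-fold lower number from compound 1 to compound 3 (0.24 log units; within the scatter) and a 1.3-fold higher number from compound 2 to compound 3 (0.10 log units; within the scatter) stay inside it. Within the data shown here, no measured compound carries a methoxy at this carbon, so the methoxy itself is untested. What is shown is that hydrogen, fluoro and chloro are all accepted there with at most a modest shift in this assay. No movement beyond the scatter is therefore expected here, the estimated step being a 1.2-fold higher number from compound 3 to compound 4 (0.09 log units; within the scatter). For compound 4 the expected value is 1.1 nM, with a range from 0.4 nM to 3 nM.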

Compound 4, inhibition constant: 1.65 nM
Estimate against measurement, compound 4: 1.5-fold (0.18 log units) below, within the range that was stated.
By their numbers in this assay, from the lowest: compounds 2, 3, 1 and 4 (each within the scatter of the next, the first and the last beyond it).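

In this assay, the 4-methoxybenzyl group extends the range at this aromatic carbon from single atoms to a two-heavy-atom group carrying a hydrogen-bond acceptor, and the methoxy cannot be separated from chloro (a 1.8-fold higher number from compound 3 to compound 4 (0.26 log units; within the scatter)) or from hydrogen (a 1.1-fold higher number from compound 1 to compound 4 (0.02 log units; within the scatter)). Only the comparison with fluoro passes the scatter (a 2.3-fold higher number from compound 2 to compound 4 (0.37 log units; beyond the scatter)), and that gap remains modest, so this carbon accepts the methoxy without any large loss and the fluoro of compound 2 keeps only a small margin over the methoxy of compound 4. No supporting evidence on hand accounts for this gap between fluoro and methoxy.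

On these data alone, it remains open whether the same acceptance extends to a longer alkoxy chain such as ethoxy or butoxy, or to a hydroxyl, an amine or a carboxylic acid at this carbon. The compounds shown also leave open whether methoxy or fluoro would be accepted equally at the other carbons of this aromatic ring, and whether these small differences would hold with another group in place of the 4-fluorophenyl sulfonyl.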